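The source may hold more compounds than are shown below. What is called first, only, known or untested is meant among the compounds shown, and "the series" means these compounds.

Compound 1, `COc1cc(C(=O)c2sc(-c3ccc(Cl)cc3)cc2N)cc(OC)c1OC`: 77 nM
Compound 2, `COc1cc(C(=O)c2sc(-c3ccc(F)cc3)cc2N)cc(OC)c1OC`: 12 nM

Two compounds that share one core and differ only in the group on the pendant six-membered ring have been measured in a functional assay on MOLT-4 cells (Homo sapiens) for antiproliferative activity; a higher number here means a weaker inhibitor, a lower number a stronger inhibitor. Going by the values given here, compound 2 stands at the lowest of the two numbers; its nearest neighbour is compound 1, and the single step between them, a 6.4-fold lower number from compound 1 to compound 2 (0.81 log units; beyond the scatter), lies beyond the scatter. Compound 3, `COc1cc(C(=O)c2sc(-c3ccc([N+](=O)[O-])cc3)cc2N)cc(OC)c1OC`, is the next member of the set. It differs from compound 2 by nitro in place of fluoro on an aromatic carbon. Among the compounds with values here, the only measured step that bears on this change is the one from compound 1 to compound 2, an exchange of one halogen for another at the same aromatic carbon; it shows that what sits at this position moves the number by a modest but real amount. Within the data shown here, nothing measured so far holds a nitro group, so the direction for compound 3 is uncertain; the expected step is a 3.3-fold higher number from compound 2 to compound 3 (0.52 log units; beyond the scatter), a drift upward relative to compound 2 given that the smaller fluoro gave 12 nM and the larger chloro on compound 1 gave 77 nM. Compound 3 is therefore estimated at 40 nM, within 8 nM to 200 nM.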

Compound 3, half-maximal inhibitory concentration: 110 nM
Estimate against measurement, compound 3: 2.8-fold (0.44 log units) below; measured number inside the range.
By their numbers in this assay, from the lowest: compound 2; then compounds 1 and 3 (each within the scatter of the next).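

Replacing fluoro with nitro on this carbon of the 4-fluorophenyl group in this assay gives a 9.2-fold higher number from compound 2 to compound 3 (0.96 log units; beyond the scatter), so a second group, one that is not a halogen, now stands well away from fluoro in the same direction as chloro. Nitro and chloro cannot be told apart here, as a 1.4-fold higher number from compound 1 to compound 3 (0.15 log units; within the scatter) shows, and among these three compounds compound 2 alone stands apart from the others, with the lowest number. No measurement is available that would account for the difference between fluoro and the other two groups.

The compounds shown leave open whether the low number belongs to fluoro alone, or whether a plain hydrogen, a methyl group, a methoxy group or an amine on this same carbon would reach it too. They also leave open whether fluoro would keep its lead over chloro and nitro on a different core.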